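Thiadiazolyl for benzothiazolyl on the sulfur linker

The source may report more compounds than this note shows. Statements on the series, on what has been measured and on what is new or still open speak of the compounds shown alone.

In a functional assay on KYSE-70 cells for antiproliferative activity against KYSE-70 cell line (Homo sapiens), read by MTT assay, with a stated time of 72 h (on this read-out higher numbers stand for weaker inhibition and lower numbers for stronger inhibition), compound 1 `C#CCSc1nc(Sc2nnnn2CCN(C)C)c(C#N)c(-c2cccc(Cl)c2)n1` gives 5320 nM. Compound 2 `C#CCSc1nc(Sc2nc3ccccc3s2)c(C#N)c(-c2cc(OC)c(OC)c(OC)c2)n1` reaches only a limit of this assay, > 20000 nM, which is the limit of > 20000 nM in this assay, at which 1 of the 2 values shown sits. Compound 3 `C#CCSc1nc(Sc2nncs2)c(C#N)c(-c2cc(OC)c(OC)c(OC)c2)n1` differs from compound 2 by 1,3,4-thiadiazol-2-yl in place of 1,3-benzothiazol-2-yl on a sulfur. Going by the values given here, no measured pair covers such a change, so the direction of the step is open. With compound 2 at a limit, the step is expected to be modest, an at least 1.1-fold lower number from compound 2 to compound 3 (0.04 log units; that floor lies within the scatter), and a second limit is as likely as a number. Compound 3 is estimated at 18000 nM, with a range from 5000 nM to 60000 nM.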

Compound 3, half-maximal inhibitory concentration: 8250 nM
For compound 3 the middle estimate is 2.2-fold (0.34 log units) above the measured one; low and high end bracket the measured number.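

The group on this sulfur matters: in this assay, 1,3,4-thiadiazol-2-yl in place of 1,3-benzothiazol-2-yl gives an at least 2.4-fold lower number from compound 2 to compound 3 (0.38 log units; beyond the scatter). This first step read at this position turns a limit into a number, with the smaller single ring on the active side of the pair. The full size of the step stays unknown because compound 2 stands at a limit: the limit of > 20000 nM in this assay, at which 1 of the 3 values shown sits.

On these data alone, whether a simple phenyl or a 1,3-oxazol-2-yl on the same sulfur would follow the thiadiazolyl remains open. So does whether the exchange carries over to the aryl group of compound 1.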